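Butyl in place of 4-methylphenyl on a carbonyl carbon

The source may hold more compounds than are shown below. What is called first, only, known or untested is meant among the compounds shown, and "the series" means these compounds.

Among the compounds with values here, in a physicochemical assay for solubility, read by HPLC (a lower number here means a less soluble compound, a higher number a more soluble compound), compound 2 `Cc1ccc(C(=O)N2CCN(c3nc(=O)c4cc(C(F)(F)F)cc([N+](=O)[O-])c4s3)CC2)cc1` gives 6.7 ug/mL, the higher of the two numbers measured so far. Within the data shown here, the only other measured compound, compound 1 `O=C(CC1CCCCC1)N1CCN(c2nc(=O)c3cc(C(F)(F)F)cc([N+](=O)[O-])c3s2)CC1`, gives 0.12 ug/mL. Compound 3 `CCCCC(=O)N1CCN(c2nc(=O)c3cc(C(F)(F)F)cc([N+](=O)[O-])c3s2)CC1` has not yet been measured. It carries butyl in place of 4-methylphenyl on a carbonyl carbon.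

Among the measured compounds shown here, one measured step bears on this change: a 56-fold higher number from compound 1 to compound 2 (1.75 log units; beyond the scatter). This large step, beyond the scatter, brought in 4-methylphenyl in place of cyclohexylmethyl on the same kind of carbonyl carbon. The new change removes 4-methylphenyl again, so a lower number in this assay is expected. Butyl is not cyclohexylmethyl, however, and the data do not show how much of the measured step would be reversed. A moderate fall is therefore expected, rather than a full return. The estimated step is a 2.7-fold lower number from compound 2 to compound 3 (0.43 log units; beyond the scatter), well short of the measured one. For compound 3 the estimated solubility is 2.5 ug/mL, with an expected range of 0.5 ug/mL to 12 ug/mL.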

Compound 3, solubility: 42.5 ug/mL
Beside the measured number, compound 3's estimate is 17-fold (1.23 log units) below it; measured number outside the range, above it.
By their numbers in this assay, from the lowest: compound 1; then compound 2; then compound 3.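

In this assay, the place on a carbonyl carbon whose other neighbour is an amide-type nitrogen in a ring turns out not to depend on 4-methylphenyl for a high number, as the first step alone might have suggested: butyl in its place gives a 6.3-fold higher number from compound 2 to compound 3 (0.80 log units; beyond the scatter). Seen from the other side, propyl in place of cyclohexyl on the saturated chain carbon bound to that carbonyl carbon gives a 350-fold higher number from compound 1 to compound 3 (2.55 log units; beyond the scatter), the largest step among these compounds, so compound 3, the one compound here with no ring in this group, stands above both compounds that carry one, and none of the three goes against that order. No measurement to hand gives a reason for either step.

Whether the high number belongs to open chains in general or to butyl alone stays open, since butyl is the only open chain without a ring shown at this place. Going by these compounds, how a shorter chain such as ethyl, a longer chain such as hexyl, a chain ending in an amine, or cyclohexyl set directly on the carbonyl carbon would read in this assay also remains unknown.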